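The compounds below may be only part of what the source reports. "The series", "measured", "known", "first", "only" and "open" are said of these compounds alone.

Compound 3 `O=C(Nc1cc(Sc2nncs2)c(O)c2ccccc12)c1ccc(Cl)cc1` is one of three measured members of a series built on a shared core. In a functional assay on MDA-MB-231 cells (Homo sapiens) for antiproliferative activity, read by MTT assay, with a stated time of 48 h (a higher number here means a weaker inhibitor, a lower number a stronger inhibitor), compound 3 reaches only the limit of the assay, > 100000 nM. Compound 1 `Cc1nnc(Sc2cc(NC(=O)c3ccc(Cl)cc3)c3ccccc3c2O)s1` differs from compound 3 only by hydrogen in place of methyl on an aromatic carbon. In this assay compound 1 likewise gives only the limit > 100000 nM. Compound 2 `O=C(/C=C/c1ccccc1)Nc1cc(Sc2ncn[nH]2)c(O)c2ccccc12`, which carries a different amide, also gives only the limit > 100000 nM in this assay. So compound 3 stands together with the other two, as the limit of > 100000 nM in this assay, at which 3 of the 3 values shown sit, records, and the step that the two limits leave unreadable from compound 1 to compound 3 cannot be read. Compound 4 `O=C(Nc1cc(Sc2ncn[nH]2)c(O)c2ccccc12)c1ccc(Cl)cc1` differs from compound 3 by 1H-1,2,4-triazol-5-yl in place of 1,3,4-thiadiazol-2-yl on a sulfur. Among the measured compounds shown here, no measured step addresses this exchange directly, but compound 2 already bears the (1H-1,2,4-triazol-5-yl)sulfanyl group and sits at the limit. Compound 4 is therefore expected to remain at the limit, with a step that the limit leaves unreadable from compound 3 to compound 4 amounting to no step beyond the scatter. The estimate for compound 4 is 150000 nM, in the range 40000 nM to 600000 nM.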

Compound 4, half-maximal inhibitory concentration: 25700 nM
Compound 4: the middle estimate sits 5.8-fold (0.77 log units) above what was measured; the whole stated range lies above it.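

In this assay the group on the sulfur proves able to move the result: 1H-1,2,4-triazol-5-yl in place of 1,3,4-thiadiazol-2-yl gives an at least 3.8-fold lower number from compound 3 to compound 4 (0.59 log units; beyond the scatter), and in place of 5-methyl-1,3,4-thiadiazol-2-yl it gives an at least 3.8-fold lower number from compound 1 to compound 4 (0.59 log units; beyond the scatter). The (1H-1,2,4-triazol-5-yl)sulfanyl group does not do this in every amide, for 4-chlorophenyl in place of 2-phenylethenyl on the carbonyl carbon gives an at least 3.8-fold lower number from compound 2 to compound 4 (0.59 log units; beyond the scatter). Among the compounds shown, only the pairing of these two groups yields a number rather than a limit: the limit of > 100000 nM in this assay, at which 3 of the 4 values shown sit.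

On these data alone, the true size of all three steps stays open, and the step among the compounds at the limit cannot be read. Also open, as far as these compounds go, is whether a methyl on the 1H-1,2,4-triazol-5-yl, or an amine in place of the chlorine of the 4-chlorophenyl, would lower the number further.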